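Methyl for chloro on the benzyl group: compound 4

A few compounds are considered here, and "the series" means these few. Any claim that something is new, unique, unknown or untested is made for them only; others in the source may bear on it.

Measured so far:
compound 1 `CSCC[C@H](NC(=O)c1ccc(NCc2cncn2Cc2cccc(C)c2)cc1-c1ccccc1)C(=O)O`; in a functional assay on NIH3T3 cells (Mus musculus) (on this read-out higher numbers stand for an effect only at larger amounts of compound and lower numbers for an effect already at smaller amounts), compound 1 gives > 10 uM, a limit of the assay rather than a number.
compound 2 `CSCC[C@H](NC(=O)c1ccc(NCc2cncn2Cc2ccc(C)cc2)cc1-c1ccccc1)C(=O)O`; in this assay compound 2 gives > 10 uM, again only a limit.
compound 3 `CSCC[C@H](NC(=O)c1ccc(NCc2cncn2Cc2ccccc2Cl)cc1-c1ccccc1)C(=O)O`; in this assay compound 3 gives > 10 uM, once more a limit and not a number.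

Among the compounds with values here, compound 3 therefore stands nowhere readable among the three: every value so far is a limit, as summed up in the limit of > 10 uM in this assay, at which 3 of the 3 values shown sit. The steps between the measured compounds carry no size for the same reason: a step that the two limits leave unreadable from compound 1 to compound 2, a step that the two limits leave unreadable from compound 1 to compound 3 and a step that the two limits leave unreadable from compound 2 to compound 3 all run from one limit to another.

Compound 4 `CSCC[C@H](NC(=O)c1ccc(NCc2cncn2Cc2ccccc2C)cc1-c1ccccc1)C(=O)O` is the next member. It differs from compound 3 by methyl in place of chloro on an aromatic carbon. The changes among the measured compounds also sat at that position on the benzyl group, and none of them moved any value off the limit, so no direction and no size can be read for the new step. The working expectation is that compound 4 will again reach the limit in this assay, and the expected step is a step that the limit leaves unreadable from compound 3 to compound 4, nothing beyond the scatter. Compound 4 is estimated at 20 uM, with a range from 5 uM to 100 uM.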

Compound 4, concentration for half-maximal effect: > 10 uM
Compound 4 ended at the assay's limit; the forecaster's own chance of this, stated with the estimate: 85%; the middle value is on the limit's open side.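

No new step can be read: the steps to compound 4 from compound 1, compound 2 and compound 3 in this assay all run between limits, and the series sits at one limit throughout: the limit of > 10 uM in this assay, at which 4 of the 4 values shown sit.

The compounds shown leave open where any of the four lies past that limit, and so whether changing the substituent on the benzyl group alters the effect at all.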